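The source may hold more compounds than are shown below. What is called first, only, known or untested is meant among the compounds shown, and "the series" means these compounds.

Two compounds share a common core and differ only in one group on one of their aromatic rings. Compound 1 `CCC(=O)N1N=C(c2ccc(F)cc2)CC1c1ccccc1` carries a fluoro group there, and in an assay on isolated protein for inhibition of Amine oxidase [flavin-containing] B (Bos taurus) (a higher number here means a weaker inhibitor, a lower number a stronger inhibitor), compound 1 gives 200 nM. Compound 2 `CCC(=O)N1N=C(c2ccc(OC)cc2)CC1c1ccccc1` carries a methoxy group in its place, and in this assay compound 2 gives 25100 nM. That single exchange produced a 130-fold higher number from compound 1 to compound 2 (2.10 log units; beyond the scatter), so compound 2 stands as the weaker of the two measured inhibitors and its number is the highest of the pair.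

Compound 3 `CCC(=O)N1N=C(c2ccc(OC)cc2)CC1c1ccc(F)cc1` is the next step out from compound 2. Its change is fluoro in place of hydrogen on an aromatic carbon. Among the compounds with values here, this fluoro group sits on the other aromatic ring, the one that was left untouched between compound 1 and compound 2, so no measured step speaks to it directly; the only measured step concerns a different ring and a different exchange. Without a comparable pair to lean on, the expectation is that compound 3 changes little from compound 2 in this assay, with an expected step of a 1.4-fold lower number from compound 2 to compound 3 (0.14 log units; within the scatter). Compound 3 is therefore estimated at 18000 nM, within a range of 5000 nM to 70000 nM.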

Compound 3, half-maximal inhibitory concentration: 100000 nM
For compound 3 the middle estimate is 5.6-fold (0.74 log units) below the measured one, and the stated range ends below it.
By their numbers in this assay, from the lowest: compound 1; then compound 2; then compound 3.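

Compound 3 shows that the aromatic ring left untouched between compound 1 and compound 2 also matters: the change from phenyl to 4-fluorophenyl gives a 4.0-fold higher number from compound 2 to compound 3 (0.60 log units; beyond the scatter) in this assay. This step is modest, yet it shows that even one fluorine atom, placed on an aromatic carbon para to a large group, can make this inhibitor weaker on a core that already carries the methoxy group. The evidence available offers no explanation for this loss, so the data record the direction and size of the step but not its cause.

The compounds shown leave open whether the same fluoro exchange would raise the number to a similar extent on the core of compound 1, where a fluoro group rather than a methoxy group occupies the other ring. They also leave open how this position would respond to other groups, such as a chloro group, a methoxy group or an amine, and so whether the step is particular to fluoro or is seen with substitution here more generally.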